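The source may hold more compounds than are shown below. What is called first, only, known or untested is meant among the compounds shown, and "the series" means these compounds.

Measured so far in a physicochemical assay for lipophilicity; on this read-out lower numbers stand for lower lipophilicity and higher numbers for higher lipophilicity:

- compound 1 `CCn1cnc2c(-c3ccc(F)c(-c4cccnc4)c3)cnnc21` gives 2.6
- compound 2 `CCn1cnc2c(-c3ccc(F)c(Oc4cccc(S(=O)(=O)CC)c4)c3)cnnc21` gives 2.3
- compound 3 `CCn1cnc2c(-c3ccc(F)c(OCc4ccccn4)c3)cnnc21` gives 2.5

Compound 3, at 2.5, lies within the usual scatter of both compound 1 and compound 2, so these three cannot be ranked against each other.

Going from compound 3 to compound 4 `CCn1cnc2c(-c3ccc(F)c(Oc4ccc(C#N)cn4)c3)cnnc21` alters one part of the molecule: 5-cyanopyridin-2-yl in place of (pyridin-2-yl)methyl on an oxygen on an aromatic ring. In words, 5-cyanopyridin-2-yl takes the place of (pyridin-2-yl)methyl on an oxygen on an aromatic ring, so that (pyridin-2-yl)methoxy becomes (5-cyanopyridin-2-yl)oxy.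

Going by the values given here, no measured pair shows this exact exchange. The nearest evidence is one step, a number 0.10 log units lower from compound 1 to compound 3 (within the scatter), which stayed within the scatter but involves different groups, so it is only a rough guide. Compound 2 also carries an aromatic ring on that oxygen, and compound 2 gives 2.3, which is again within the scatter of the others. Since the different groups measured so far have not moved this assay beyond the scatter, no step beyond the scatter is expected here.

The expected step is a number 0.10 log units lower from compound 3 to compound 4 (within the scatter). For compound 4 the estimate is 2.4, with an expected range from 2 to 2.8.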

Compound 4, distribution coefficient: 2.3
Compound 4: middle estimate off by 0.10 log units, on the high side; measured number inside the range.
By their numbers in this assay, from the lowest: compounds 2, 4, 3 and 1 (each within the scatter of the next).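

In this assay, the exchange of (pyridin-2-yl)methyl for 5-cyanopyridin-2-yl on the oxygen brings in a nitrile and gives a number 0.20 log units lower from compound 3 to compound 4 (within the scatter), so this change in the group on the oxygen does not separate the two compounds. Setting (5-cyanopyridin-2-yl)oxy in place of pyridin-3-yl on the aromatic carbon gives a number 0.30 log units lower from compound 1 to compound 4 (within the scatter), which extends the same finding to a comparison of two quite different groups at this place. Nothing measured here accounts for the size of these steps.

The compounds shown leave open whether any group at this place can move the read-out beyond the scatter, for example an amine, a carboxylic acid or a longer alkyl chain on the oxygen. The step from compound 3 to compound 4 also joins two differences, the nitrile and the methyl link in (pyridin-2-yl)methyl, so a plain pyridin-2-yl on the oxygen would be needed to look at each one alone.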